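The compounds below may be only part of what the source reports. "The series", "measured", "known", "first", "only" and "open" are said of these compounds alone.

In a functional assay on U-251 cells (Homo sapiens) for cytotoxicity, read by sulforhodamine B assay, with a stated time of 48 h (a lower number here means a stronger inhibitor of growth, a higher number a weaker inhibitor of growth), compound 1 `ClCc1cccc(Cn2cnc3ncnc(Cl)c32)c1` gives 3980 nM. Compound 2 `ClCc1ccccc1Cn1cnc2ncnc(Cl)c21` is built from the same atoms joined differently; the difference between the two cores is not broken down here. In this assay compound 2 gives 4360 nM, and the two values lie within the scatter of each other. Compound 3 `ClCc1cccc(Cn2cnc3nc(Cl)nc(Cl)c32)c1` carries one change relative to compound 1, (chloro in place of hydrogen on an aromatic carbon), and in this assay compound 3 gives 2690 nM, so that the step is a 1.5-fold lower number from compound 1 to compound 3 (0.17 log units; within the scatter).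

Compound 4 `ClCc1ccccc1Cn1cnc2nc(Cl)nc(Cl)c21` is not yet measured. It stands to compound 2 as compound 3 stands to compound 1: the change is chloro in place of hydrogen on an aromatic carbon, and the surroundings of the place are described in the same words in both cases, so the change is taken to be the same. Because the step of a 1.5-fold lower number from compound 1 to compound 3 (0.17 log units; within the scatter) stayed within the scatter, the expected step from compound 2 to compound 4 is small, a 1.5-fold lower number from compound 2 to compound 4 (0.18 log units; within the scatter). On that basis compound 4 is estimated to give about 2900 nM in this assay, expected to fall between 1500 nM and 6000 nM.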

Compound 4, concentration for total growth inhibition: 1170 nM
Compound 4: the middle estimate sits 2.5-fold (0.39 log units) above what was measured, and the stated range ends above it.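

In this assay, chloro in place of hydrogen on an aromatic carbon between two ring nitrogen atoms gives a 3.7-fold lower number from compound 2 to compound 4 (0.57 log units; beyond the scatter), so on this core the change has an effect that stands clear of the scatter, which its counterpart on the core of compound 1 does not. Set side by side, the two steps cannot be told apart, and the series gives no ground for saying that the change acts differently on the two cores: the same change on two cores in this assay, a 1.5-fold lower number (0.17 log units; within the scatter) from compound 1 to compound 3 and a 3.7-fold lower number (0.57 log units; beyond the scatter) from compound 2 to compound 4, 2.5-fold (0.40 log units) apart, within the scatter of two such steps. This does not show that the change carries over unaltered, since two pairs are too few to fix its size, and they offer no explanation for the gap between the steps or any rule for other cores.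

The compounds shown leave open what an amine, a methoxy group or a longer chain would do at that same place in place of the chloro. They also leave open whether a carboxylic acid there would fit the same picture on either core.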